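Sulfonamide surrogate for the tetrazole in a pituitary cell assay

The compounds below may be only part of what the source reports. "The series", "measured", "known", "first", "only" and "open" are said of these compounds alone.

Compound 1 `CC(C)(N)CC(=O)N[C@@H]1CCc2ccccc2N(Cc2ccc(-c3ccccc3-c3nnn(CC(=O)O)n3)cc2)C1=O`: 0.2 uM
Compound 2 `CC(C)(N)CC(=O)N[C@@H]1CCc2ccccc2N(Cc2ccc(-c3ccccc3-c3nnnn3Cc3ccccc3)cc2)C1=O`: 0.7 uM
Compound 3 `CC(C)(N)CC(=O)N[C@@H]1CCc2ccccc2N(Cc2ccc(-c3ccccc3-c3nnnn3CC(=O)O)cc2)C1=O`: 1 uM

In a functional assay (Pituitary gland cell) with Rattus norvegicus as the target (a higher number here means that more compound is needed for the effect, a lower number that less compound is needed), compound 3 has the highest of the three numbers: it sits within the scatter of compound 2, but clearly apart from compound 1, as seen in a 5.0-fold higher number from compound 1 to compound 3 (0.70 log units; beyond the scatter). Compound 4 `CC(C)(N)CC(=O)N[C@@H]1CCc2ccccc2N(Cc2ccc(-c3ccccc3S(=O)(=O)NC(=O)c3ccccc3)cc2)C1=O` carries benzoylsulfamoyl in place of 1-(carboxymethyl)-1H-tetrazol-5-yl on an aromatic carbon, placed ortho to a large group. Among the measured compounds shown here, no measured pair repeats this change; the steps at the same position, a 3.5-fold higher number from compound 1 to compound 2 (0.54 log units; beyond the scatter) and a 5.0-fold higher number from compound 1 to compound 3 (0.70 log units; beyond the scatter), were modest, and a 1.4-fold higher number from compound 2 to compound 3 (0.15 log units; within the scatter) stayed within the scatter. Compound 4 is therefore expected to move only modestly, most likely toward a lower number, a 2.0-fold lower number from compound 3 to compound 4 (0.30 log units; within the scatter). The estimate for compound 4 in this assay is 0.5 uM, with a range from 0.1 uM to 2.5 uM.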

Compound 4, concentration for half-maximal effect: 3 uM
Estimate against measurement, compound 4: 6.0-fold (0.78 log units) below; measured number above the stated range.
By their numbers in this assay, from the lowest: compound 1; then compounds 2 and 3 (each within the scatter of the next); then compound 4.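

In this assay, benzoylsulfamoyl on this aromatic carbon, ortho to a large group, gave a 3.0-fold higher number from compound 3 to compound 4 (0.48 log units; beyond the scatter), a 4.3-fold higher number from compound 2 to compound 4 (0.63 log units; beyond the scatter) and a 15-fold higher number from compound 1 to compound 4 (1.18 log units; beyond the scatter). Among the compounds shown here, this is the only large step at this position, and compound 4, the one compound here without a tetrazole, has the highest number of the four, beyond the scatter of each of the others. No supporting data bear on why this shift arises. On these data alone, it remains open whether the phenyl ring of the benzoyl or the sulfamoyl link carries the step, and how an acetyl in place of that benzoyl, or a carboxylic acid directly on this aromatic carbon, would compare.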